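From 3-methylbenzyl to a sulfonyl group on compound 1

A few compounds are considered here, and "the series" means these few. Any claim that something is new, unique, unknown or untested is made for them only; others in the source may bear on it.

For the measured compounds named here, in a functional assay on NALM-6 cells (Homo sapiens) for antiproliferative activity, read by MTT assay and trypan blue exclusion, with a stated time of 72 h (a lower number here means a stronger inhibitor, a higher number a weaker inhibitor), compound 1 (`COC(=O)c1ccc(C2SCC(=O)N2c2ccc(N3CCN(Cc4cccc(C)c4)CC3)cn2)c(OC)c1`) gives 27300 nM, the only true number so far. Compound 2 (`COC(=O)c1ccc(C2SCC(=O)N2c2ccc(N3CCN(S(=O)(=O)c4ccc(F)cc4)CC3)cn2)c(OC)c1`) gives > 100000 nM, which is a limit of the assay and not a number. Compound 3 (`COC(=O)c1ccc(C2SCC(=O)N2c2ccc(N3CCN(S(=O)(=O)c4cc(Cl)ccc4Cl)CC3)cn2)c(OC)c1`) is still unmeasured; its change is (2,5-dichlorophenyl)sulfonyl in place of 3-methylbenzyl on an amine nitrogen in a ring. Going by the values given here, the one measured step that bears on it, also replacing 3-methylbenzyl with a sulfonyl group, is an at least 3.6-fold higher number from compound 1 to compound 2 (0.56 log units; beyond the scatter). A move to a higher number in this assay is therefore expected, and the expected step is a 2.6-fold higher number from compound 1 to compound 3 (0.41 log units; beyond the scatter). For compound 3 the estimated value is 70000 nM, within a range of 20000 nM to 150000 nM.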

Compound 3, half-maximal inhibitory concentration: 27400 nM
Beside the measured number, compound 3's estimate is 2.6-fold (0.41 log units) above it; low and high end bracket the measured number.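

In this assay, a sulfonyl group on this ring nitrogen does not by itself raise the number: a 1.0-fold higher number from compound 1 to compound 3 (0.00 log units; within the scatter). What the sulfonyl sulfur carries makes the difference, with an at least 3.6-fold lower number from compound 2 to compound 3 (0.56 log units; beyond the scatter). Compound 2 stands at a limit of the assay and not at a number: the limit of > 100000 nM in this assay, at which 1 of the 3 values shown sits.

Which of the two chlorine atoms in the 2,5-dichlorophenyl group matters, if either does, remains open. So does whether an amide carbonyl or a methylsulfonyl group on this nitrogen would behave the same way.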